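The source may report more compounds than this note shows. Statements on the series, on what has been measured and on what is new or still open speak of the compounds shown alone.

Values measured in a functional assay on the whole organism (strain Sprague-Dawley) for inhibition, with Rattus norvegicus as the target, with a stated time of 10 min; on this read-out higher numbers stand for an effect only at larger amounts of compound and lower numbers for an effect already at smaller amounts:

- compound 1 `CCOc1ccc(S(N)(=O)=O)cc1-c1ncc(C(=O)O)c(=O)[nH]1`: > 50 mg/kg (a limit of the assay, not a number)
- compound 2 `CCOC(=O)c1cnc(-c2cc(Cl)ccc2OCC)[nH]c1=O`: 0.5 mg/kg
- compound 3 `CCOC(=O)c1cnc(-c2cc(S(=O)(=O)Cl)ccc2OCC)[nH]c1=O`: "not determined" (no result reported)

Compound 3 has no place on this scale, as its entry reads "not determined" (no result reported) and no number was reported. Only two other results frame it. One is the number for compound 2, 0.5 mg/kg. The other is the limit of > 50 mg/kg in this assay, at which 1 of the 3 values shown sits, and it belongs to compound 1, for which the assay gives a limit and not a number.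

Compound 4 `CCOC(=O)c1cnc(-c2cc(S(N)(=O)=O)ccc2OCC)[nH]c1=O` has not yet been measured in this assay. One change separates it from compound 3: amino in place of chloro on a sulfonyl sulfur, which is amino in place of chloro on a sulfonyl sulfur, or chlorosulfonyl to sulfamoyl.

Among the compounds with values here, with no number for compound 3, no step from it can be sized, so the expectation has to lean on its neighbours. Compound 4 keeps the ethyl ester also found in compound 2, which gives 0.5 mg/kg, and it is therefore expected to work at low doses. Compound 4 also carries the sulfamoyl group of compound 1, so a moderate shift towards larger doses than those of compound 2 is expected, though one much smaller than the gap to the limit of compound 1.

In this assay, compound 4 is estimated at 1.5 mg/kg, with an expected range from 0.3 mg/kg to 10 mg/kg.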

Compound 4, dose for 50% inhibition: 50 mg/kg
Compound 4: middle estimate off by 33-fold (1.52 log units), on the low side; measured number above the stated range.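

In this assay, sulfamoyl in place of chloro on an aromatic carbon gives a 100-fold higher number from compound 2 to compound 4 (2.00 log units; beyond the scatter), a large change at this one position while the ethyl ester stays the same. Compound 2 alone could not show this: the ethyl ester does not by itself secure an effect at low doses, and the group on this aromatic carbon has a strong bearing on the dose needed. Ethyl in place of hydrogen on an oxygen next to a carbonyl group gives a number no higher from compound 1 to compound 4 (the limit leaves the size open). The size of this step cannot be read, as compound 1 holds a limit of the assay and not a number: the limit of > 50 mg/kg in this assay, at which 1 of the 4 values shown sits.

Within the data shown here, the weight of chlorosulfonyl to sulfamoyl on its own stays open, as compound 3 has no number in this assay and no step from it can be sized. Also open, from the compounds shown here alone, is whether a dimethylamino group on the sulfonyl sulfur, or a bromo or methoxy group in place of chloro on the aromatic carbon, would bring the dose close to that of compound 2 or leave it close to that of compound 4.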